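The source may hold more compounds than are shown below. What is called first, only, known or untested is meant among the compounds shown, and "the series" means these compounds.

Measured so far in a functional assay on PC-3 cells (Homo sapiens) for cytotoxicity, read by MTT assay, with a stated time of 5 days; a higher number here means a weaker inhibitor of growth, a lower number a stronger inhibitor of growth

- compound 1 `Cc1ccc(NS(=O)(=O)c2ccccc2)c([N+](=O)[O-])c1` gives 60300 nM
- compound 2 `Cc1ccc(NC(=O)c2ccc(C)cc2)cc1` gives 26900 nM
- compound 3 `Cc1ccc(NS(=O)(=O)c2ccccc2)cc1` gives 13800 nM

Of these three, compound 1 has the highest number, and both other compounds lie lower by more than the scatter. Compound 3 is the furthest from it and compound 2 the nearest.

Compound 4 `Cc1ccc(NS(=O)(=O)c2ccc(F)cc2)c([N+](=O)[O-])c1` has not yet been measured. It differs from compound 1 by one change, (fluoro in place of hydrogen on an aromatic carbon), which is fluoro in place of hydrogen on an aromatic carbon, turning phenyl to 4-fluorophenyl.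

For the measured compounds named here, only one measured step starts from compound 1, and that is a 4.4-fold lower number from compound 1 to compound 3 (0.64 log units; beyond the scatter), a modest change with hydrogen in place of nitro. It concerns a different group, so it offers only a rough idea of how far a single substitution can move this series. Going by the values given here, no measured pair shows fluoro in place of hydrogen. A step beyond the scatter in this assay is therefore not expected, in either direction.

The expected step is a 1.2-fold lower number from compound 1 to compound 4 (0.08 log units; within the scatter), and this is only an estimate. For compound 4 the estimated value is 50000 nM, with an expected range from 22000 nM to 100000 nM.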

Compound 4, concentration for 50% growth inhibition: 850 nM
Compound 4: the middle estimate sits 59-fold (1.77 log units) above what was measured, and the stated range ends above it.
By their numbers in this assay, from the lowest: compound 4; then compounds 3 and 2 (each within the scatter of the next); then compound 1.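

In this assay, the change from phenyl to 4-fluorophenyl, which adds a single fluorine atom para to a large group, gives a 71-fold lower number from compound 1 to compound 4 (1.85 log units; beyond the scatter). For the compounds shown here, the only earlier step, a 4.4-fold lower number from compound 1 to compound 3 (0.64 log units; beyond the scatter), involved the nitro group in a different place, so this result is the first to show that the phenyl ring is also sensitive to substitution, and that a one-atom change there can move the number further than removing the nitro group does. Nothing at hand accounts for the size of this step, which remains an observation from a single pair of compounds.

Going by these compounds, it remains open whether the step is specific to fluoro or would also appear with another group in the same place, such as chloro, methoxy or an amine, and whether fluoro elsewhere on the ring would do the same. It is also unknown whether the step depends on the nitro group, a question that only a 4-fluorophenyl compound with hydrogen in place of nitro could settle.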